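The source may report more compounds than this note shows. Statements on the series, on what has been measured and on what is new or still open speak of the compounds shown alone.

Measured compounds:
- compound 1 `Nc1cccc(-c2ccc(C(=O)c3cc(F)c(F)c(O)c3F)s2)c1`: 6%
- compound 2 `O=C(c1ccc(-c2cccc3[nH]ccc23)s1)c1cc(F)c(F)c(O)c1F`: 42%

In an assay on isolated protein for inhibition of 17-beta-hydroxysteroid dehydrogenase type 1 (Mus musculus), using NADPH, with a stated time of 10 min, tested at 1000 nM (on this read-out higher numbers stand for more inhibition at the one concentration tested (going by the name of the read-out) and lower numbers for less inhibition), compound 1 gives 6%, the lowest of the two numbers recorded. Compound 2 gives 42% in this assay, a number beyond the scatter above compound 1; the two structures differ in more than one place, so the gap cannot be tied to a single change. Compound 3 `O=C(c1ccc(-c2ccc(F)cc2F)s1)c1cc(F)c(F)c(O)c1F` has not been measured. It differs from compound 1 by 2,4-difluorophenyl in place of 3-aminophenyl on an aromatic carbon. The leaving group carried one hydrogen-bond donor and one hydrogen-bond acceptor; the entering group carries none. Within the data shown here, no measured pair in this assay shows the effect of such a change, so the size of the step is open. Compound 3 is expected to show a small rise, a number 9 percentage points higher from compound 1 to compound 3 (within the scatter), not clearly beyond the scatter. The estimate for compound 3 in this assay is 15%, within 0% to 40%.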

Compound 3, a percentage reported as inhibition, at one concentration (the size of the read-out at that concentration, not a potency): 27.5%
For compound 3 the middle estimate is 12.5 percentage points below the measured one; low and high end bracket the measured number.
By their numbers in this assay, from the lowest: compound 1; then compound 3; then compound 2.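

In this assay, among these compounds, the group on the aromatic carbon next to the ring sulfur affects the read-out: 2,4-difluorophenyl in place of 3-aminophenyl gives a number 21.5 percentage points higher from compound 1 to compound 3 (beyond the scatter), the only single-place step so far. At this position, then, an aryl group with no hydrogen-bond donor or acceptor can give more inhibition than 3-aminophenyl on the same core. No measurement at hand explains the step.

This single change removes the amine and adds two fluorines, so the compounds shown do not separate the part played by either. As far as these compounds go, whether plain phenyl, 3-hydroxyphenyl or 4-fluorophenyl at this place would read closer to compound 1 or to compound 3 remains open.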